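A Methyl Step Tested Twice on One Urea Series

A few compounds are considered here, and "the series" means these few. Any claim that something is new, unique, unknown or untested is made for them only; others in the source may bear on it.

Compound 1 `CC(C)(C)c1cc(NC(=O)Nc2cc(C(F)(F)F)cc(C(F)(F)F)c2)n(-c2ccccc2)n1` and compound 2 `Cc1ccc(-n2nc(C(C)(C)C)cc2NC(=O)Nc2cc(C(F)(F)F)cc(C(F)(F)F)c2)cc1` share one core; compound 3 `CC(C)(C)c1cc(NC(=O)Nc2cc(F)cc(F)c2)n(-c2ccccc2)n1` and the not yet measured compound 4 `Cc1ccc(-n2nc(C(C)(C)C)cc2NC(=O)Nc2cc(F)cc(F)c2)cc1` share another, and the difference between the two cores is not broken down here. In an assay on isolated protein for inhibition of STE20-like serine/threonine-protein kinase (Homo sapiens), read by thermal shift assay, tested at 10 uM (on this read-out higher numbers stand for stronger stabilisation of the target against heat and lower numbers for weaker stabilisation of the target), compound 1 gives 0 degrees C, compound 2 gives 0 degrees C and compound 3 gives 3 degrees C. The change from compound 1 to compound 2 is methyl in place of hydrogen on an aromatic carbon and the step it made was no change at the digits printed from compound 1 to compound 2 (within the scatter). The change from compound 3 to compound 4 is methyl in place of hydrogen on an aromatic carbon, the same change at a place described in the same words. Since the earlier step read no change at the digits printed from compound 1 to compound 2 (within the scatter), the expected step is no change at the digits printed from compound 3 to compound 4 (within the scatter). Compound 4 is therefore estimated at 3 degrees C, with a likely range from 1 degrees C to 5 degrees C.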

Compound 4, shift of the target's melting temperature: 2.8 degrees C
Compound 4: middle estimate off by 0.20 degrees C, on the high side; measured number inside the range.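

In this assay, for the compounds shown here, the methyl step reads a number 0.20 degrees C lower from compound 3 to compound 4 (within the scatter), and it can be set beside the same step on the other core: the same change on two cores in this assay, no change at the digits printed (within the scatter) from compound 1 to compound 2 and a number 0.20 degrees C lower (within the scatter) from compound 3 to compound 4, 0.20 degrees C apart, within the scatter of two such steps The change from phenyl to 4-methylphenyl therefore carried over between these two cores, with no step beyond the scatter on either, although compound 1 gives 0 degrees C and compound 3 gives 3 degrees C. This is only one change at one place, seen on two cores in this assay, so it does not show that the methyl would behave the same way on any other core, nor why it behaves this way here.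

The compounds shown leave open whether a longer chain, an amine or a carboxylic acid at that same place would also leave the melting-temperature shift unchanged.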